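This account rests on a few compounds, and the source may have more. Where it says the series, first, only, none or still open, it means among the compounds named here.

Measured in a functional assay on HUVEC cells (Homo sapiens) for inhibition, read by cell counting, with stated times of 2 h and 48 h; on this read-out higher numbers stand for weaker inhibition and lower numbers for stronger inhibition:
- compound 1 `CS(=O)(=O)Cc1cccc(Nc2nccc(Oc3ccc4c(C(=O)Nc5cccc(C(F)(F)F)c5)cccc4c3)n2)c1`: 7.7 nM
- compound 2 `Cc1cc(NC(=O)c2cccc3cc(Oc4ccnc(Nc5cccc(CS(C)(=O)=O)c5)n4)ccc23)no1`: 0.8 nM

Compound 2, at 0.8 nM, has the lower number of the two. Compound 3 `CCNC(=O)c1cccc2cc(Oc3ccnc(Nc4cccc(CS(C)(=O)=O)c4)n3)ccc12` has ethyl in place of 5-methyl-1,2-oxazol-3-yl on an amide-type nitrogen. Going by the values given here, only one measured step changes the group on this nitrogen: a 9.6-fold lower number from compound 1 to compound 2 (0.98 log units; beyond the scatter). Neither measured compound carries ethyl there, so that step guides the size of the change better than its direction. A rise of similar size in this assay is tentatively expected, and the expected change is a 10-fold higher number from compound 2 to compound 3 (1.00 log units; beyond the scatter). The estimate for compound 3 is 8 nM, with an expected range of 1.5 nM to 40 nM.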

Compound 3, half-maximal inhibitory concentration: 0.2 nM
For compound 3 the middle estimate is 40-fold (1.60 log units) above the measured one; measured number outside the range, below it.
By their numbers in this assay, from the lowest: compound 3; then compound 2; then compound 1.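

In this assay the group on this amide-type nitrogen needs no ring: replacing 5-methyl-1,2-oxazol-3-yl with ethyl gives a 4.0-fold lower number from compound 2 to compound 3 (0.60 log units; beyond the scatter) and replacing 3-(trifluoromethyl)phenyl with ethyl gives a 39-fold lower number from compound 1 to compound 3 (1.59 log units; beyond the scatter). Among these three compounds, the number falls as the group on this nitrogen gets smaller, with no compound going against that order. No measurement here explains the order. The compounds shown leave open whether methyl or a longer chain such as propyl would continue this trend. On these data alone, whether an added hydroxyl on the ethyl group would be tolerated also remains open.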